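The compounds below may be only part of what the source reports. "The series", "measured", "known", "first", "only" and "open" are said of these compounds alone.

Compound 2 `COc1ccc(C2(NC(=O)CN3CCN(C)CC3)C(=O)Nc3cc(Cl)c(C)cc32)cc1` gives 525 nM in an in vitro functional assay on CHO-CREluc cells for antagonist activity at growth hormone secretagogue receptor type 1 (Homo sapiens), read by a luciferase reporter, with a stated time of 4 h (a lower number here means a stronger inhibitor, a higher number a weaker inhibitor), the lowest of the two numbers obtained in the series. Compound 1 `Cc1cc2c(cc1Cl)NC(=O)C2(NC(=O)CN1CCN(C)CC1)c1cccc(Cl)c1` gives 1180 nM, so that a 2.2-fold lower number from compound 1 to compound 2 (0.35 log units; beyond the scatter). Compound 3 `Cc1cc2c(cc1Cl)NC(=O)C2(NC(=O)CN1CCN(C)CC1)c1ccccc1Cl` sits at the assay limit of > 10000 nM in this assay. Compound 4 `COc1ccc(C2(NC(=O)CN3CCN(C)CC3)C(=O)Nc3cc(Cl)c(Cl)cc32)cc1` keeps the 4-methoxyphenyl of compound 2 and differs on the shared core: chloro in place of methyl on an aromatic carbon. The measured steps of an at least 8.4-fold higher number from compound 1 to compound 3 (0.92 log units; beyond the scatter) and an at least 19-fold higher number from compound 2 to compound 3 (1.27 log units; beyond the scatter), like the first, all vary the aryl on the saturated ring carbon; none alters the fused ring, and none therefore bears directly on this change. With compound 2 as anchor, the expected step of a 1.1-fold lower number from compound 2 to compound 4 (0.02 log units; within the scatter) is none beyond the scatter. Compound 4 is estimated at 500 nM, with a range from 200 nM to 1300 nM.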

Compound 4, half-maximal inhibitory concentration: 700 nM
Beside the measured number, compound 4's estimate is 1.4-fold (0.15 log units) below it; the measured number falls inside the stated range.
By their numbers in this assay, from the lowest: compounds 2, 4 and 1 (each within the scatter of the next, the first and the last beyond it). At a limit, above all of these: compound 3.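

Going by these compounds alone, this is the first step on the shared core rather than on the aryl at the saturated ring carbon: in this assay there is a 1.3-fold higher number from compound 2 to compound 4 (0.12 log units; within the scatter) when chloro replaces methyl on the aromatic carbon ortho to a chloro group. With the 4-methoxyphenyl kept, this position accepts the exchange with no change beyond the scatter. Nothing shown gives a reason for this result.

On these data alone, whether the exchange behaves the same with the 3-chlorophenyl of compound 1 stays open. Also open, as far as these compounds go, is how an amine or a carboxylic acid at this position would read.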